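Compound 4 and the limit of the series

A few compounds are considered here, and "the series" means these few. Any claim that something is new, unique, unknown or untested is made for them only; others in the source may bear on it.

compound 1 `COc1ccc(-c2c(C)nc3c(N4CC[C@@H](NC(C)=O)C4)cc(C)nn23)cc1OC` gives > 95% (a limit)
compound 2 `CC(=O)N[C@@H]1CCN(c2cc(C)nn3c(-c4ccc(C#N)cc4)c(C)nc23)C1` gives > 95% (a limit)
compound 3 `CSc1ccc(-c2c(C)nc3c(N4CC[C@@H](NC(C)=O)C4)cc(C)nn23)cc1` gives > 95% (a limit)

In an ADME assay on microsomes from liver (Mus musculus) for metabolic stability, read by LC-MS, with NADPH named in the record, with a stated time of 60 min, tested at 1 uM, in the absence of a further agent (a higher number here means that more of the compound is left, a lower number that less of the compound is left), compound 3 stands at > 95% as a limit of the assay and not a number. The change furan-2-yl in place of 4-(methylsulfanyl)phenyl on an aromatic carbon puts furan-2-yl in place of 4-(methylsulfanyl)phenyl on an aromatic carbon in compound 4 `CC(=O)N[C@@H]1CCN(c2cc(C)nn3c(-c4ccco4)c(C)nc23)C1` and leaves the rest of the structure as it is. Three measured changes of the aromatic group bear on this: a step that the two limits leave unreadable from compound 1 to compound 2 and a step that the two limits leave unreadable from compound 1 to compound 3 and also a step that the two limits leave unreadable from compound 2 to compound 3 in the same setting. The three compounds share the limit of > 95% in this assay, at which 3 of the 3 values shown sit, and so these steps set no size. Going by the values given here, no measured compound carries a five-membered aromatic ring at this place, which leaves the expectation loose. The step that the two limits leave unreadable from compound 2 to compound 3 shows no readable loss, so no large change is expected. The expected move is small and downward, estimated as a number at least 7 percentage points lower from compound 3 to compound 4 (that floor lies within the scatter) with wide uncertainty. For compound 4 the estimated value is 88% with an expected range from 60% to 100% in this estimate.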

Compound 4, percent of the compound remaining: > 95%
Compound 4: a limit, no number (the forecaster's own chance of this, stated with the estimate: 40%); at least 7 percentage points between middle value and limit.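

No step between compound 4 and compound 1, compound 2 or compound 3 can be read, because each value is a limit of the assay and not a number: the limit of > 95% in this assay, at which 4 of the 4 values shown sit.

The compounds shown leave open whether these aromatic groups on the shared core differ at all in this assay.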